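The source may hold more compounds than are shown below. What is called first, only, known or untested is meant among the compounds shown, and "the series" means these compounds.

In a functional assay on the whole organism (strain Wistar albino) for inhibition, with Rattus norvegicus as the target, read by paw edema, with stated times of 30 min and 2 h, at a dose of 20 mg/kg by the oral route (on this read-out higher numbers stand for more inhibition at the one dose given (going by the name of the read-out) and lower numbers for less inhibition), compound 1, `CN(C)Cc1ccc2oc(-c3ccccc3Cl)cc(=O)c2c1`, gives 36.2%. Compound 2, `COc1ccc(-c2cc(=O)c3cc(CN(C)C)ccc3o2)cc1`, gives 36% in this assay, and compound 3, `COc1ccc(-c2cc(=O)c3cc(CNc4ccc(S(N)(=O)=O)cc4)ccc3o2)cc1`, gives 25.3%. Compound 1 thus carries the largest of the three numbers, but compound 2 stands within the usual scatter of it, so the two cannot be told apart; only compound 3 lies beyond the scatter below compound 1. Among the compounds with values here, compound 2 and compound 3 share the same core apart from the group on the chain carbon, and their two numbers show the one with the arylamino group falling beyond the scatter.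

Compound 4, `Cc1ccc(NCc2ccc3oc(-c4ccccc4Cl)cc(=O)c3c2)cc1`, has not been measured in this assay. Relative to compound 1 the change is (4-methylphenyl)amino in place of dimethylamino on a saturated chain carbon bound to an aromatic carbon. Going by what compound 2 and compound 3 show, a modest fall is expected, though one not clearly beyond the scatter, so the step of a number 6.2 percentage points lower from compound 1 to compound 4 (within the scatter) is estimated as small and downward. Compound 4 is therefore expected to give about 30% in this assay, within a range from 20% to 40%.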

Compound 4, a percentage reported as inhibition, in the whole organism at one dose (the size of the read-out at that dose, not a potency): 19.8%
The estimate for compound 4 lay 10.2 percentage points above the measured number, outside the stated range (below it).
By their numbers in this assay, from the lowest: compounds 4 and 3 (each within the scatter of the next); then compounds 2 and 1 (each within the scatter of the next).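

Putting (4-methylphenyl)amino in place of dimethylamino on a saturated chain carbon bound to an aromatic carbon gives, in this assay, a change of a number 16.4 percentage points lower from compound 1 to compound 4 (beyond the scatter), so the change at this place reduces inhibition on the core of compound 1 by more than the scatter. Compound 2 at 36% and compound 3 at 25.3% had shown a fall on the other core, with a different arylamino group, so such a fall now appears on both cores shown. No measurement shown bears on why the number falls.

The compounds shown leave open whether the fall goes with the aromatic ring or with the hydrogen-bond donor that enters. A methylamino group, or a methyl(4-methylphenyl)amino group, on the same chain carbon would separate the two.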